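Aryl variation on the thiosemicarbazone series: nitro to chloro

The source may report more compounds than this note shows. Statements on the series, on what has been measured and on what is new or still open speak of the compounds shown alone.

Three aryl thiosemicarbazones sharing one core have been measured. In a functional assay on UACC-62 cells (Homo sapiens) for cytotoxicity, read by sulforhodamine B assay (on this read-out higher numbers stand for lower toxicity in this test and lower numbers for higher toxicity in this test), compound 1 `CC1=CC[C@@H]([C@@](C)(O)CCCC(C)(C)NC(=S)N/N=C\c2ccc(C)cc2)CC1` gives 52300 nM, compound 2 `CC1=CC[C@@H]([C@@](C)(O)CCCC(C)(C)NC(=S)N/N=C\c2ccc(O)cc2)CC1` gives 55600 nM, and compound 3 `CC1=CC[C@@H]([C@@](C)(O)CCCC(C)(C)NC(=S)N/N=C\c2ccccc2[N+](=O)[O-])CC1` gives 49300 nM. Compound 3 holds the lowest of the three numbers, but its nearest neighbour is compound 1, a 1.1-fold lower number from compound 1 to compound 3 (0.03 log units; within the scatter), and its furthest is compound 2, a 1.1-fold lower number from compound 2 to compound 3 (0.05 log units; within the scatter); so the three values sit together within the scatter, and no order among them can be claimed.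

Compound 4 `CC1=CC[C@@H]([C@@](C)(O)CCCC(C)(C)NC(=S)N/N=C\c2ccccc2Cl)CC1` is the next member. It differs from compound 3 by chloro in place of nitro on an aromatic carbon. Among the compounds with values here, no measured step covers this exact exchange. Within the data shown here, the steps that bear on it are the aryl changes already made: a 1.1-fold higher number from compound 1 to compound 2 (0.03 log units; within the scatter), a 1.1-fold lower number from compound 1 to compound 3 (0.03 log units; within the scatter) and a 1.1-fold lower number from compound 2 to compound 3 (0.05 log units; within the scatter), each within the scatter. On that basis the step to compound 4 is expected to be a 1.0-fold higher number from compound 3 to compound 4 (0.01 log units; within the scatter), with no change beyond the scatter. Compound 4 is therefore estimated at 50000 nM in this assay, in the range 25000 nM to 100000 nM.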

Compound 4, concentration lethal to 50% of the cells: > 100000 nM
Compound 4 was reported as a limit; the forecaster's own chance of this, stated with the estimate: 10%; middle value at least 2.0-fold (0.30 log units) away from the limit.
By their numbers in this assay, from the lowest: compounds 3, 1 and 2 (each within the scatter of the next). At a limit, above all of these: compound 4.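

Compound 4 is reported as a limit of the assay and not as a number: the limit of > 100000 nM in this assay, at which 1 of the 4 values shown sits.

With chloro in place of nitro on this aromatic carbon, the reading is an at least 2.0-fold higher number from compound 3 to compound 4 (0.30 log units; that floor lies within the scatter), and the 2-chlorophenyl compound also reads an at least 1.7-fold higher number from compound 2 to compound 4 (0.25 log units; that floor lies within the scatter) and an at least 1.9-fold higher number from compound 1 to compound 4 (0.28 log units; that floor lies within the scatter). Each of these floors lies within the scatter, so the series now holds its first aryl group with an open upper side, though no separation from the other three compounds is established.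

The compounds shown leave open how far the value of compound 4 lies from the others, and so whether this exchange moves the read-out beyond the scatter. As far as these compounds go, how an amine or a methoxy group on this aromatic carbon would read in this assay, and whether chloro would read the same elsewhere on the ring, also stays open.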